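From a Nitro Group to a Methoxy Group

The source may hold more compounds than are shown below. What is called first, only, known or untested is meant among the compounds shown, and "the series" means these compounds.

Three compounds built on one shared core, carrying a nitrile, an oxime and an amide, have been measured in a physicochemical assay for acid dissociation, using potentiometric titration. Compound 1 `N#C/C(=N\O)C(=O)Nc1cc(C(F)(F)F)cc(C(F)(F)F)c1` gives 4.73. Compound 2 `N#C/C(=N\O)C(=O)Nc1cccc(F)c1` gives 4.92. Compound 3 `N#C/C(=N\O)C(=O)Nc1ccc([N+](=O)[O-])cc1` gives 4.61. The number for compound 3 lies within the scatter of the number for compound 1, while the number for compound 2 stands beyond the scatter above it. Compound 4 `COc1ccc(NC(=O)/C(C#N)=N/O)cc1` has not yet been measured in this assay. It differs from compound 3 in one place: methoxy in place of nitro on an aromatic carbon. Among the compounds with values here, no two of the measured compounds differ in only one place, so no measured step shows what such a change does in this assay. For compound 4 the expectation in this assay is a rise beyond the scatter, a number 0.49 log units higher from compound 3 to compound 4 (beyond the scatter). The estimate for compound 4 in this assay is 5.1, with a range from 4.85 to 5.35.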

Compound 4, acid dissociation constant: 5.08
The estimate for compound 4 lay 0.02 log units above the measured number; the range from low to high includes it.
By their numbers in this assay, from the lowest: compounds 3, 1, 2 and 4 (each within the scatter of the next, the first and the last beyond it).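

Within the data shown here, until now, no two measured compounds differed in only one place, so this is the first direct reading of a single change on the shared core. In this assay, methoxy in place of nitro on an aromatic carbon, para to a group of 8 heavy atoms, gives a number 0.47 log units higher from compound 3 to compound 4 (beyond the scatter). The proton is therefore given up less readily with methoxy at this position, and the step lies beyond the usual scatter, but no measurement here gives a reason for the shift.

Only these two groups can be compared at this position, so a single step says little about how other groups would behave there. An amine or a longer chain such as ethoxy on the same aromatic carbon would show whether the number in this assay stays near that of either compound or moves elsewhere.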